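The source may report more compounds than this note shows. Statements on the series, on what has been measured and on what is new or still open speak of the compounds shown alone.

Working notes on the thiosemicarbazide series.

Compound 1 `Cc1cccc(/C(N)=N/NC(=S)N2CCCCC2)n1` is the reference point. In a functional assay on A-375 cells (Homo sapiens) for cytotoxicity, read by MTT assay, with a stated time of 72 h (on this read-out higher numbers stand for weaker inhibition and lower numbers for stronger inhibition), compound 1 gives 1000 nM. Compound 2 `Cc1cccc(/C(N)=N/NC(=S)N2CCCC2)n1` carries the same core with a smaller saturated ring on the thiocarbonyl carbon; in this assay compound 2 gives 2900 nM. The change between them is pyrrolidin-1-yl in place of piperidin-1-yl on a thiocarbonyl carbon, and it produced a 2.9-fold higher number from compound 1 to compound 2 (0.46 log units; beyond the scatter).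

Compound 3 `Cc1ccnc(/C(N)=N/NC(=S)N2CCCCC2)c1` has the same atoms as compound 1, joined differently; the difference between the two cores is not broken down here. In this assay compound 3 gives 1900 nM. Against compound 1 this is a gap within the scatter, and against compound 2 likewise, so no order among compounds 1, 2 and 3 is asserted beyond the one step already given.

Compound 4 `Cc1ccnc(/C(N)=N/NC(=S)N2CCCC2)c1` is not yet measured. It stands to compound 3 as compound 2 stands to compound 1: the change is pyrrolidin-1-yl in place of piperidin-1-yl on a thiocarbonyl carbon, the same change at the same place. Within the data shown here, the only measured instance of it is the step from compound 1 to compound 2, which went beyond the scatter toward weaker inhibition. With one instance and a different core, the transfer is an assumption, not a rule; compound 3 itself shows that the core rearrangement moves the number only within the scatter.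

The expectation is that compound 4 shows a 2.7-fold higher number from compound 3 to compound 4 (0.44 log units; beyond the scatter) in this assay, because the same change gave a 2.9-fold higher number from compound 1 to compound 2 (0.46 log units; beyond the scatter). Compound 4 is estimated at 5200 nM, with a range from 2400 nM to 11000 nM.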

Compound 4, half-maximal inhibitory concentration: 720 nM
The estimate for compound 4 lay 7.2-fold (0.86 log units) above the measured number; measured number below the stated range.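

In this assay, pyrrolidin-1-yl in place of piperidin-1-yl on a thiocarbonyl carbon gives a 2.6-fold lower number from compound 3 to compound 4 (0.42 log units; beyond the scatter), so the direction seen on the core of compound 1 does not carry over to the core of compound 3. Set side by side, the two instances of this one change run in opposite directions, and the gap between them is larger than repeated measurements would explain: the same change on two cores in this assay, a 2.9-fold higher number (0.46 log units; beyond the scatter) from compound 1 to compound 2 and a 2.6-fold lower number (0.42 log units; beyond the scatter) from compound 3 to compound 4, 7.7-fold (0.88 log units) apart, beyond the scatter of two such steps

This shows that, within these two pairs, the outcome of the ring change depends on the core that carries it, so a step measured on one core is no guide to the sign of the step on the other; it does not show which feature of the two cores is responsible, and two pairs give no rule for any third core.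

Still open, going by these compounds, is whether a larger or hetero-atom-bearing amine on the thiocarbonyl carbon, such as azepan-1-yl or morpholin-4-yl, would follow the trend of the core of compound 1, that of the core of compound 3, or neither. Also open, on these data alone, is whether the reversal persists when the methyl group on the core gives way to an ethyl group or a chlorine atom.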